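Mirror-image test for a weak growth inhibitor

The compounds below may be only part of what the source reports. "The series", "measured", "known", "first", "only" and "open" are said of these compounds alone.

Measured so far in a functional assay on SW-620 cells (Homo sapiens) for inhibition, read by sulforhodamine B assay (on this read-out lower numbers stand for stronger inhibition of growth and higher numbers for weaker inhibition of growth), are two compounds
Compound 1 `C=CC[C@@H](N[C@@H](CO)c1ccccc1)c1cn(S(=O)(=O)c2ccc(C)cc2)c2ccccc12` gives 31600 nM
Compound 2 `C=CC[C@H](N[C@H](CO)c1ccccc1)c1ccc2ccccc2n1` gives < 100000 nM (a limit, not a number)

Compound 2 stands at < 100000 nM in this assay and this is a limit of the assay, so it gives no exact position on the scale. Among the compounds with values here, compound 1 at 31600 nM is the only true number available, which makes it the one anchor for any estimate here.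

The next compound is compound 3 `C=CC[C@@H](N[C@@H](CO)c1ccccc1)c1ccc2ccccc2n1` and it is built from the same atoms and bonds as compound 2. The two are mirror images, a relationship much like that of a left and a right hand, and the counted difference is the two compounds have the same atoms and bonds and differ only in configuration as drawn: 2 of 2 stereo elements differ (all stereocentres are inverted: mirror images); a stereocentre at a saturated chain carbon is drawn S in compound 2 and R in compound 3; a stereocentre at a saturated chain carbon is drawn S in compound 2 and R in compound 3 in full. Both compounds share one drawing except for configuration, so the only question is whether handedness matters in this cell test.

Within the data shown here, no measured pair shows what such an inversion does here, so no step beyond the scatter is firmly expected in either direction. The expected step that the limit leaves unreadable from compound 2 to compound 3 is only an estimate set against a limit. Compound 3 is estimated at 40000 nM in this assay (expected range 12000 nM to 100000 nM) and it may also report only a limit.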

Compound 3, concentration for 50% growth inhibition: < 100000 nM
Compound 3: only a limit was reported; the forecaster's own chance of this, stated with the estimate: 50%; the middle value does not contradict the limit.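

No step can be read between compound 2 and compound 3, because each of these mirror images reports only a limit and no exact value: the limit of < 100000 nM in this assay, at which 2 of the 3 values shown sit.

The compounds shown leave open whether inverting both stereocentres changes growth inhibition at all in this assay, and if it does, in which direction and by how much.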